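Swapping the chain amine at the end of a propoxy linker

The source may report more compounds than this note shows. Statements on the series, on what has been measured and on what is new or still open speak of the compounds shown alone.

Three compounds share the same core and were tested in a functional assay on HT-29 cells (Homo sapiens) for inhibition, read by MTT assay, with a stated time of 72 h; a lower number here means a stronger inhibitor, a higher number a weaker inhibitor. Compound 1 `COc1cc2c(Oc3ccc(NC(=O)c4nn(-c5ccccc5)c(=O)cc4C)cc3F)ccnc2cc1OCCCN1CCN(C)CC1` gives 270 nM in this assay. Within the data shown here, compound 2 `COc1ccc(-n2nc(C(=O)Nc3ccc(Oc4ccnc5cc(OCCCN6CCN(C)CC6)c(OC)cc45)c(F)c3)c(C)cc2=O)cc1` gives 3520 nM, and the step of a 13-fold higher number from compound 1 to compound 2 (1.12 log units; beyond the scatter) is the one measured step in the set. Compound 3 `COc1cc2c(Oc3ccc(NC(=O)c4nn(-c5ccc(Cl)cc5)c(=O)cc4C)cc3F)ccnc2cc1OCCCN1CCC(C)CC1` gives 180 nM, the lowest of the three numbers; the gap to compound 1 lies within the scatter, while the gap to compound 2 lies beyond it.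

Compound 4 `COc1cc2c(Oc3ccc(NC(=O)c4nn(-c5ccc(Cl)cc5)c(=O)cc4C)cc3F)ccnc2cc1OCCCN1CCN(C)CC1` has not yet been measured in this assay. It differs from compound 3 by 4-methylpiperazin-1-yl in place of 4-methylpiperidin-1-yl on a saturated chain carbon, three bonds along the chain from an oxygen on an aromatic ring. Among the measured compounds shown here, no measured step in this set changes the chain amine, so the only step on record, the one from compound 1 to compound 2, concerns a different part of the molecule and does not bear on this change. Compound 1 already carries the 4-methylpiperazin-1-yl group and sits within the scatter of compound 3. For compound 4 the expected step of a 1.2-fold higher number from compound 3 to compound 4 (0.09 log units; within the scatter) is therefore none beyond the scatter. Compound 4 is estimated at 220 nM in this assay, in a range from 90 nM to 550 nM.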

Compound 4, half-maximal inhibitory concentration: 320 nM
Compound 4: the middle estimate sits 1.5-fold (0.16 log units) below what was measured; measured number inside the range.
By their numbers in this assay, from the lowest: compounds 3, 1 and 4 (each within the scatter of the next); then compound 2.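

Across this assay, the swap of 4-methylpiperidin-1-yl for 4-methylpiperazin-1-yl gives the first direct reading at this chain position, and the step stays within the scatter (a 1.8-fold higher number from compound 3 to compound 4 (0.25 log units; within the scatter)). With 4-methylpiperazin-1-yl held in place, chloro in place of hydrogen on an aromatic carbon also stays within the scatter (a 1.2-fold higher number from compound 1 to compound 4 (0.07 log units; within the scatter)), while chloro in place of methoxy at that carbon is a large step (an 11-fold lower number from compound 2 to compound 4 (1.04 log units; beyond the scatter)), so among compounds 1, 2 and 4 only compound 2, with its methoxy, stands apart. Nothing on hand explains why these steps differ in size.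

From the compounds shown here alone, whether a morpholine or a dimethylamino group at the end of the propyl chain would also stay within the scatter remains open. So does whether a fluoro or a methyl group at the chloro carbon would track chloro or methoxy.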